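Difluorophenyl Replaces Dichlorophenyl Against an Unbroken Cytotoxicity Ceiling

A few compounds are considered here, and "the series" means these few. Any claim that something is new, unique, unknown or untested is made for them only; others in the source may bear on it.

The study compares three compounds that share a core and differ in the group attached to a sulfur on a saturated chain carbon: compound 1 `COc1ccc(-c2nc(C[S+]([O-])c3cccc(Cl)c3)nc3ccsc23)cn1`, compound 2 `COc1ccc(-c2nc(CSCc3cccc(Cl)c3)nc3ccsc23)cn1` and compound 3 `COc1ccc(-c2nc(CSc3cc(Cl)ccc3Cl)nc3ccsc23)cn1`. In an ADME assay on cells (Homo sapiens) for cytotoxicity, read by resazurin assay, with a stated time of 5 days (on this read-out lower numbers stand for higher toxicity in this test and higher numbers for lower toxicity in this test), compound 1 gives > 50000 nM, which is a limit of the assay rather than a number. In this assay compound 2 gives > 50000 nM, again a limit. In this assay compound 3 gives > 50000 nM, also a limit. Compound 3 thus stands at the ceiling of what the test reports, and the limit of > 50000 nM in this assay, at which 3 of the 3 values shown sit, records that every value shown rests there. The steps a step that the two limits leave unreadable from compound 1 to compound 3 and a step that the two limits leave unreadable from compound 2 to compound 3 are consequently of unreadable size.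

Compound 4 `COc1ccc(-c2nc(CSc3ccc(F)cc3F)nc3ccsc23)cn1` has not yet been measured. It differs from compound 3 by 2,4-difluorophenyl in place of 2,5-dichlorophenyl on a sulfur. Among the measured compounds shown here, no measured step bears on this change with a readable size, since every value shown is a limit, so the account expects no step beyond the scatter, estimating a number no higher from compound 3 to compound 4 (the limit leaves the size open). Compound 4 is therefore expected to give 50000 nM in this assay, within 20000 nM to 100000 nM, most likely reported once more as a limit.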

Compound 4, half-maximal cytotoxic concentration: > 50000 nM
Compound 4: a limit, no number; the forecaster's own chance of this, stated with the estimate: 85%; the middle value lies on the limit itself.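

Compound 4 gives > 50000 nM in this assay, a limit and not a number, so no step from compound 1, compound 2 or compound 3 to compound 4 can be read: the limit of > 50000 nM in this assay, at which 4 of the 4 values shown sit.

The compounds shown leave open at what concentration any of them would become toxic to these cells, and whether changing the group on the sulfur alters that concentration.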